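Terminal anilide of compound 1: fluoro to methyl

The source may report more compounds than this note shows. Statements on the series, on what has been measured and on what is new or still open speak of the compounds shown alone.

Measured so far:
compound 1 `Cc1nc2c(F)cc(-c3nc(Nc4ccc(NC(=O)C5(C(=O)Nc6ccc(F)cc6)CC5)cc4)ncc3F)cc2n1C(C)C`: 191 nM
compound 2 `Cc1nc2c(F)cc(-c3nc(Nc4ccc(NC(=O)C5(C(=O)Nc6cccc(F)c6)CC5)cc4)ncc3F)cc2n1C(C)C`: 106 nM

In a functional assay on HeLa cells (Homo sapiens) for antiproliferative activity, read by CCK-8 assay, with a stated time of 72 h (a lower number here means a stronger inhibitor, a higher number a weaker inhibitor), compound 1 gives 191 nM, the higher of the two numbers; compound 2 gives 106 nM, and the step of a 1.8-fold lower number from compound 1 to compound 2 (0.26 log units; within the scatter) is within the scatter. Compound 3 `Cc1ccc(NC(=O)C2(C(=O)Nc3ccc(Nc4ncc(F)c(-c5cc(F)c6nc(C)n(C(C)C)c6c5)n4)cc3)CC2)cc1` differs from compound 1 by methyl in place of fluoro on an aromatic carbon. Going by the values given here, no measured step exchanges the fluoro for another group; the only measured step, a 1.8-fold lower number from compound 1 to compound 2 (0.26 log units; within the scatter), moves the fluoro and stays within the scatter. For compound 3 no step beyond the scatter is therefore expected, a 1.1-fold lower number from compound 1 to compound 3 (0.03 log units; within the scatter). The estimate for compound 3 is 180 nM, range 70 nM to 450 nM.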

Compound 3, half-maximal inhibitory concentration: 71.5 nM
The estimate for compound 3 lay 2.5-fold (0.40 log units) above the measured number; low and high end bracket the measured number.
By their numbers in this assay, from the lowest: compounds 3, 2 and 1 (each within the scatter of the next, the first and the last beyond it).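

In this assay, going by these compounds alone, the change from 4-fluorophenyl to 4-methylphenyl gives, with a 2.7-fold lower number from compound 1 to compound 3 (0.43 log units; beyond the scatter), the first step beyond the scatter on this terminal ring, so the group para to the large group does register in this read-out. The 4-methylphenyl and 3-fluorophenyl anilides remain indistinguishable, with a 1.5-fold lower number from compound 2 to compound 3 (0.17 log units; within the scatter), so the methyl has no separable standing against compound 2. Nothing available explains the difference between methyl and fluoro.

Open, from the compounds shown here alone, is whether 4-chlorophenyl, 4-methoxyphenyl or 4-aminophenyl would follow the methyl or the fluoro. Also open, going by these compounds, is how a 3-methylphenyl would compare.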